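A few compounds are considered here, and "the series" means these few. Any claim that something is new, unique, unknown or untested is made for them only; others in the source may bear on it.

Measured so far:
- compound 1, `CCCCCCCCCCCCCCCCSCC(COP(=O)(O)OP(=O)(O)OC[C@H]1OC(n2ccc(N)nc2=O)[C@@H](O)[C@@H]1O)OC(=O)CCCCCCCCCCCCCCC`: 200000 nM
- compound 2, `CCCCCCCCCCCCCCCCSCC(COP(=O)(O)OP(=O)(O)OC[C@H]1OC(n2ccc(N)nc2=O)[C@@H](O)[C@@H]1O)OC(=O)CCCCCCCCCCCCC`: > 53000000 nM

The two measured compounds share one core and differ only in the length of a saturated chain. In an ADME assay for solubility (on this read-out lower numbers stand for lower solubility and higher numbers for higher solubility), compound 1 gives 200000 nM. For compound 2 this assay reports only a limit, > 53000000 nM, and no number. For the measured compounds named here, the one measured step, an at least 260-fold higher number from compound 1 to compound 2 (2.42 log units; beyond the scatter), runs from the ethyl-bearing compound 1 to the hydrogen-bearing compound 2, and it places compound 2 at the limit of > 53000000 nM in this assay, at which 1 of the 2 values shown sits.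

Compound 3, `CCCCCCCCCCCCCCCCCC(=O)OC(COP(=O)(O)OP(=O)(O)OC[C@H]1OC(n2ccc(N)nc2=O)[C@@H](O)[C@@H]1O)CSCCCCCCCCCCCCCCCC`, has not yet been measured in this assay. It differs from compound 2 by butyl in place of hydrogen on a saturated chain carbon, ten or more bonds along the chain from a carbonyl carbon. This is the reverse direction of the measured step, and it goes further: where compound 1 carries an ethyl at that position, compound 3 carries a butyl. Since the loss of ethyl raised the number in this assay by an at least 260-fold higher number from compound 1 to compound 2 (2.42 log units; beyond the scatter), adding butyl is expected to lower it, and by a step that is large. The expected step for compound 3 is an at least 880-fold lower number from compound 2 to compound 3 (2.94 log units; beyond the scatter), a number somewhat under that of compound 1. Compound 3 is therefore estimated at 60000 nM, with a range from 5000 nM to 1000000 nM.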

Compound 3, solubility: 200000 nM
Beside the measured number, compound 3's estimate is 3.3-fold (0.52 log units) below it, within the range that was stated.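

Putting butyl in place of hydrogen on this saturated chain carbon moves this assay by a large amount, with an at least 260-fold lower number from compound 2 to compound 3 (2.42 log units; beyond the scatter), so the step first seen with ethyl also appears with a second, longer group. What compound 3 adds is that the size of the group, once it is ethyl or butyl, makes no visible difference here, with no change at the digits printed from compound 1 to compound 3 (within the scatter), so among these compounds the change looks more like a split between hydrogen and the two longer groups than a steady slide with each added carbon. On these data alone, the real size of the drop stays unknown, because compound 2 gives only a limit and not a number: the limit of > 53000000 nM in this assay, at which 1 of the 3 values shown sits.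

As far as these compounds go, whether a methyl at this position already brings the full drop, or only part of it, remains open, and so does the true distance between compound 2 and the other two compounds. A longer chain such as hexyl, or an amine or a carboxylic acid placed on this chain, could show whether the number stays where compound 1 and compound 3 sit or moves again.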